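Chloro in Place of Methyl, Seen Twice on One Core

A few compounds are considered here, and "the series" means these few. Any claim that something is new, unique, unknown or untested is made for them only; others in the source may bear on it.

Measured so far:
Compound 1 `Cc1ccc2c(c1)C1(C(=O)N2Cc2ccccc2)C(C#N)=C(N)Oc2cc3oc(-c4ccccc4)cc(=O)c3c(O)c21` gives > 50000 nM in a functional assay on K562 cells (Homo sapiens) for antiproliferative activity, read by MTT assay, with a stated time of 48 h; a lower number here means a stronger inhibitor, a higher number a weaker inhibitor; that is a limit of the assay, not a number.
Compound 2 `Cc1cccc2c1N(Cc1ccccc1)C(=O)C21C(C#N)=C(N)Oc2cc3oc(-c4ccccc4)cc(=O)c3c(O)c21` gives > 50000 nM in this assay; that too is a limit, not a number.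
Compound 3 `N#CC1=C(N)Oc2cc3oc(-c4ccccc4)cc(=O)c3c(O)c2C12C(=O)N(Cc1ccccc1)c1ccc(Cl)cc12` gives 36300 nM in this assay.

The difference between the cores of compound 1 and compound 2 is not broken down here. From compound 1 to compound 3 the change is chloro in place of methyl on an aromatic carbon, and the step is an at least 1.3-fold lower number from compound 1 to compound 3 (0.13 log units; that floor lies within the scatter). What can be said of its size rests on (the limit of > 50000 nM in this assay, at which 2 of the 3 values shown sit), so only a floor is known.

Compound 4 `N#CC1=C(N)Oc2cc3oc(-c4ccccc4)cc(=O)c3c(O)c2C12C(=O)N(Cc1ccccc1)c1c(Cl)cccc12` is not yet measured. It differs from compound 2 by chloro in place of methyl on an aromatic carbon. This is the same kind of change as that from compound 1 to compound 3, not the same: there the chloro stands meta and para to a fused ring, here ortho and meta to a fused ring.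

Because compound 2 sits at a limit > 50000 nM, compound 4 is expected at 45000 nM in this assay, within 20000 nM to 100000 nM, an expected step of an at least 1.1-fold lower number from compound 2 to compound 4 (0.04 log units; that floor lies within the scatter).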

Compound 4, half-maximal inhibitory concentration: 47800 nM
Estimate against measurement, compound 4: 1.1-fold (0.03 log units) below, within the range that was stated.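

Putting chloro in place of methyl on the core of compound 2 gives an at least 1.0-fold lower number from compound 2 to compound 4 (0.01 log units; that floor lies within the scatter) in this assay, which is only a floor on the size of the step. Set beside the same change on the core of compound 1, this gives no sign that the two steps match or differ: the same change on two cores in this assay, an at least 1.3-fold lower number (0.13 log units; that floor lies within the scatter) from compound 1 to compound 3 and an at least 1.0-fold lower number (0.01 log units; that floor lies within the scatter) from compound 2 to compound 4; the limit leaves it open whether they differ The change therefore cannot be said to carry over from one core to the other with the same size, and the true size of each step stays unknown because both methyl compounds rest on a limit: the limit of > 50000 nM in this assay, at which 2 of the 4 values shown sit.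

Only methyl and chloro appear at these two places in the compounds shown, so what an amine, a carboxylic acid or a longer chain would give there stays open. Also open, as far as these compounds go, is where compound 1 and compound 2 truly lie, as only a limit is known for each.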